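Swapping the group on the carbonyl of compound 1

A few compounds are considered here, and "the series" means these few. Any claim that something is new, unique, unknown or untested is made for them only; others in the source may bear on it.

Values from a functional assay on KETR3 cells (Homo sapiens) for inhibition, read by MTT assay, with a stated time of 120 h (a lower number here means a stronger inhibitor, a higher number a weaker inhibitor), are as follows
- compound 1 (`C/C(=C\c1ccc(NC(=O)Nc2ccc(Cl)c(C(F)(F)F)c2)cc1)C(=O)NC(C)c1ccccc1`) > 50000 nM (a limit, not a number)
- compound 2 (`CC(NC(=O)/C=C/Oc1ccc(NC(=O)Nc2cc(C(F)(F)F)ccc2Cl)cc1)c1ccccc1`) 16400 nM
- compound 3 (`CC(NC(=O)c1ccc(-c2ccc(NC(=O)Nc3ccc(Cl)c(C(F)(F)F)c3)cc2)cc1)c1ccccc1`) 19300 nM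

Compound 1 gives > 50000 nM as a limit of the assay and not as a number. That places compound 1 at the limit of > 50000 nM in this assay, at which 1 of the 3 values shown sits, in this small set. Compound 2 with 16400 nM and compound 3 with 19300 nM lie within the usual scatter of each other.

Compound 4 (`C/C(=C\c1ccc(NC(=O)Nc2ccc(Cl)c(C(F)(F)F)c2)cc1)C(=O)N1CC(C)OC(C)C1`) keeps the core of compound 1 and changes one group on a carbonyl carbon: 2,6-dimethylmorpholin-4-yl in place of (1-phenylethyl)amino on a carbonyl carbon with 2,6-dimethylmorpholin-4-yl in place of (1-phenylethyl)amino. A ring of carbon only thus gives way to a non-aromatic ring with hetero atoms.

Among the measured compounds shown here, no measured pair shows what such a swap does in this assay and compound 1 offers no exact starting number. No step beyond the scatter is therefore expected, in either direction. The nearest real numbers are compound 2 at 16400 nM and compound 3 at 19300 nM and they mark the lower end of what seems likely. The expected change is an at least 1.2-fold lower number from compound 1 to compound 4 (0.09 log units; that floor lies within the scatter) and this is only an estimate. For compound 4 the estimate is 40000 nM with an expected range from 15000 nM to 50000 nM in this assay.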

Compound 4, half-maximal inhibitory concentration: > 50000 nM
Compound 4: no number, only a limit; the forecaster's own chance of this, stated with the estimate: 55%; at least 1.2-fold (0.09 log units) between middle value and limit.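

In this assay compound 4 gives > 50000 nM as a limit of the assay and not as a number. Among the compounds shown here, compound 1 also stands at a limit, so no step from compound 1 to compound 4 can be read. The compounds shown leave open how far, if at all, 2,6-dimethylmorpholin-4-yl in place of (1-phenylethyl)amino on a carbonyl carbon changes inhibition.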